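A few compounds are considered here, and "the series" means these few. Any claim that something is new, unique, unknown or untested is made for them only; others in the source may bear on it.

Measured in a functional assay on LNCaP cells (Homo sapiens) for antiproliferative activity, read by MTT assay, with a stated time of 48 h; a lower number here means a stronger inhibitor, a higher number a weaker inhibitor:
Compound 1 `O=C1NC2(C3=C(C(=O)C4C=CC=CC4C3=O)c3ccccc32)c2ccccc21`: 670 nM
Compound 2 `O=C1NC2(C3=C(C(=O)C4C=CC=CC4C3=O)c3ccccc32)c2cc(Cl)c(Cl)cc21`: 1100 nM

Going by the values given here, these two values lie within the usual scatter of each other, so compound 1 stands level with compound 2 on the numbers so far. Compound 3 `O=C1NC2(C3=C(C(=O)C4C=CC=CC4C3=O)c3cc(Cl)ccc32)c2ccccc21` keeps the core of compound 1 and carries chloro in place of hydrogen on an aromatic carbon. Among the compounds with values here, no measured step shows this change, so no step beyond the scatter is expected in this assay. The estimate amounts to an expected step of a 1.2-fold higher number from compound 1 to compound 3 (0.08 log units; within the scatter). For compound 3 the estimated value is 800 nM, with an expected range from 330 nM to 1900 nM.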

Compound 3, half-maximal inhibitory concentration: 5340 nM
Compound 3: the middle estimate sits 6.7-fold (0.82 log units) below what was measured, outside the stated range (above it).
By their numbers in this assay, from the lowest: compounds 1 and 2 (each within the scatter of the next); then compound 3.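

In this assay, going by these compounds alone, chloro in place of hydrogen on an aromatic carbon of the core of compound 1 gives an 8.0-fold higher number from compound 1 to compound 3 (0.90 log units; beyond the scatter) and so provides the first step here that lies beyond the scatter. At this position, the change from hydrogen to chloro costs activity in this assay. No measurement shown bears on why the step has this size. On these data alone, whether fluoro, methyl or methoxy at the same carbon would give a similar step remains open. So does the effect of an amine there.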